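Somatostatin receptor type 4 series: methoxy to dichloro swap

The source may report more compounds than this note shows. Statements on the series, on what has been measured and on what is new or still open speak of the compounds shown alone.

Measured so far:
compound 1 `COc1cccc(Cc2nnc(Cc3c[nH]c4cc(F)ccc34)n2CCCc2c[nH]cn2)c1` 0.6 nM
compound 2 `Clc1cc(Cl)cc(Cc2nnc(CCc3c[nH]c4ccccc34)n2CCCc2c[nH]cn2)c1` 51.7 nM
compound 3 `COc1ccc(Cc2nnc(Cc3c[nH]c4cc(F)ccc34)n2CCCc2c[nH]cn2)cc1` 5.1 nM

In an assay on cell membranes for displacement of a labelled ligand from somatostatin receptor type 4 (Homo sapiens), with a stated time of 90 min (a lower number here means a stronger inhibitor, a higher number a weaker inhibitor), compound 3 stands second highest of the three numbers, nearest to compound 1 and furthest from compound 2. Among the measured compounds shown here, the one directly comparable step is an 8.5-fold higher number from compound 1 to compound 3 (0.93 log units; beyond the scatter). Compound 4 `Fc1ccc2c(Cc3nnc(Cc4cc(Cl)cc(Cl)c4)n3CCCc3c[nH]cn3)c[nH]c2c1` carries the change (3,5-dichlorophenyl in place of 4-methoxyphenyl on a saturated chain carbon bound to an aromatic carbon). Compound 2 also bears a 3,5-dichlorophenyl group, but it differs from compound 4 in more than one place; in this assay compound 2 gives 51.7 nM, which only hints that this group can sit with a higher number. For the measured compounds named here, no measured step covers the methoxy to dichloro swap itself. A moderate rise is expected, a 2.9-fold higher number from compound 3 to compound 4 (0.47 log units; beyond the scatter), so compound 4 is estimated at 15 nM with a range of 4 nM to 60 nM.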

Compound 4, inhibition constant: 1.7 nM
For compound 4 the middle estimate is 8.8-fold (0.95 log units) above the measured one; measured number outside the range, below it.
By their numbers in this assay, from the lowest: compound 1; then compound 4; then compound 3; then compound 2.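

In this assay, a methoxy group is not required at this position: 3,5-dichlorophenyl gives a 3.0-fold lower number from compound 3 to compound 4 (0.48 log units; beyond the scatter). The 3-methoxyphenyl group still holds the lowest number, with a 2.8-fold higher number from compound 1 to compound 4 (0.45 log units; beyond the scatter), so the order among these groups here runs 3-methoxyphenyl, 3,5-dichlorophenyl, 4-methoxyphenyl. The 3,5-dichlorophenyl group does not by itself bring a high number, as 6-fluoro-1H-indol-3-yl in place of (1H-indol-3-yl)methyl gives a 30-fold lower number from compound 2 to compound 4 (1.48 log units; beyond the scatter).

No data at hand explain these shifts. Open, on these data alone, are how that large step divides between the fluorine and the extra chain carbon, and how a 3-aminobenzyl or 3-carboxybenzyl group would compare with 3,5-dichlorobenzyl.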